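N-methylation step in the hydrazone series

The compounds below may be only part of what the source reports. "The series", "measured", "known", "first", "only" and "open" are said of these compounds alone.

Two compounds of this series have a number in a functional assay on cells (Mus musculus) for cytotoxicity, read by MTT assay, with a stated time of 24 h, tested at 1 uM; on this read-out higher numbers stand for a stronger effect at the one concentration tested and lower numbers for a weaker effect. Compound 1 `COc1cc(/C=N/N(C)c2nc3ccccc3s2)cc(OC)c1O` carries a methyl on the hydrazone nitrogen and two methoxy groups on the phenol; in this assay compound 1 gives 107%. Compound 2 `COc1cc(/C=N/Nc2nc3ccccc3s2)ccc1O` carries a free hydrazone nitrogen and a single methoxy group on the phenol; in this assay compound 2 gives 44%. Going by the values given here, compound 2 therefore stands lowest of the two numbers, with compound 1 as its only neighbour and well beyond the scatter above it. Among the compounds with values here, compound 1 and compound 2 differ in two places at once, so no single step between them can be read.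

Compound 3 `COc1cc(/C=N/N(C)c2nc3ccccc3s2)ccc1O` has not been measured. It differs from compound 2 as follows: methyl in place of hydrogen on a nitrogen on an aromatic ring. This brings compound 3 to the same hydrazone nitrogen pattern as compound 1, while keeping the phenol of compound 2. Within the data shown here, with no single-change step in hand, the expected direction is upward, towards the number of compound 1, and of a size beyond the scatter; the expected step from a number 36 percentage points higher from compound 2 to compound 3 (beyond the scatter) reflects this, though with wide uncertainty. In this assay compound 3 is estimated at 80%, within a range from 50% to 110%.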

Compound 3, a percentage reported as activity, at one concentration (the size of the read-out at that concentration, not a potency): 96%
Compound 3: middle estimate off by 16 percentage points, on the low side; the range from low to high includes it.
By their numbers in this assay, from the lowest: compound 2; then compound 3; then compound 1.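

In this assay, going by these compounds alone, the single change of methyl in place of hydrogen on a nitrogen on an aromatic ring gives a number 52 percentage points higher from compound 2 to compound 3 (beyond the scatter), a large step that can now be read on its own rather than mixed with a second change. The other single change, hydrogen in place of methoxy on an aromatic carbon, gives a number 11 percentage points lower from compound 1 to compound 3 (beyond the scatter), a modest step, so of the two differences separating compound 1 from compound 2, the methyl on the nitrogen carries the large step and the methoxy the modest one. Nothing at hand gives a cause for either step, and the size of the methyl step stands here as an observation only.

On these data alone, only hydrogen and methyl have been compared at this nitrogen, so an ethyl group or a longer chain there, or a group such as an acetyl, remains open. On the aromatic carbon, only methoxy and hydrogen are compared, which leaves open how an amine or a carboxylic acid in place of the methoxy would read at the one concentration tested.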